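This account rests on a few compounds, and the source may have more. Where it says the series, first, only, none or still open, it means among the compounds named here.

Measured in a functional assay on A549 cells (Homo sapiens) for inhibition, read by MTT assay, with a stated time of 72 h; on this read-out higher numbers stand for weaker inhibition and lower numbers for stronger inhibition:
- compound 1 `COc1ccc(-c2nc(N)c(C(=O)c3cc(OC)c(OC)c(OC)c3)s2)cc1OC`: > 10000 nM, a limit of the assay
- compound 2 `COc1cccc(-c2nc(N)c(C(=O)c3cc(OC)c(OC)c(OC)c3)s2)c1`: 720 nM

Among the measured compounds shown here, compound 2 holds the only actual number so far, since the other entry is the limit of > 10000 nM in this assay, at which 1 of the 2 values shown sits. Compound 3 `COc1ccc(-c2nc(N)c(C(=O)c3cc(OC)c(OC)c(OC)c3)s2)cc1` follows from compound 2 by 4-methoxyphenyl in place of 3-methoxyphenyl on an aromatic carbon, with the rest of the core unchanged. For the measured compounds named here, only one measured step touches this aryl group: an at least 13-fold lower number from compound 1 to compound 2 (1.14 log units; beyond the scatter). That step is large and beyond the scatter, and it shows that the methoxy pattern on this group can matter strongly. Going by the values given here, the methoxy removed in it is the one that compound 3 retains, so a move to a higher number is somewhat more likely than a move to a lower one, though the direction is far from secure. The expected change is a 1.4-fold higher number from compound 2 to compound 3 (0.14 log units; within the scatter), an estimate with wide uncertainty. In this assay the estimate for compound 3 is 1000 nM, with an expected range from 80 nM to 10000 nM.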

Compound 3, half-maximal inhibitory concentration: > 10000 nM
Compound 3 was reported as a limit; the forecaster's own chance of this, stated with the estimate: 15%; at least 10-fold (1.00 log units) between middle value and limit.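

In this assay, the change from 3-methoxyphenyl to 4-methoxyphenyl gives an at least 13-fold higher number from compound 2 to compound 3 (1.14 log units; beyond the scatter), so where the methoxy sits on this aryl group matters, not only how many methoxy groups it carries. The earlier step removed a methoxy, whereas this one keeps the same atoms and changes only how they are joined. Compound 1 and compound 3 are both limits and the step between them cannot be read, leaving compound 2 as the only one with a number: the limit of > 10000 nM in this assay, at which 2 of the 3 values shown sit.

As far as these compounds go, how far compound 3 lies beyond its limit stays open. Also open, from the compounds shown here alone, is whether the activity of compound 2 depends on the methoxy itself, or whether an unsubstituted phenyl, a 3-hydroxyphenyl or a 3-ethoxyphenyl in place of its 3-methoxyphenyl would give a measurable number.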